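The source may report more compounds than this note shows. Statements on the series, on what has been measured and on what is new or still open speak of the compounds shown alone.

Measured compounds:
- compound 1, `CC(C)Cc1csc(N)c1C(=O)c1ccc(Cl)cc1`: 1%
- compound 2, `CC(C)(C)Cc1c(-c2c(F)cccc2F)sc(N)c1C(=O)c1ccc(Cl)cc1`: 1%
- compound 3, `Cc1ccc(C(=O)c2c(N)sc(-c3ccccc3)c2CC(C)(C)C)cc1`: 1%

Within the data shown here, the three compounds measured so far share a common core and were all tested in an assay on CHO cells for displacement of a labelled ligand from adenosine receptor A1 (Homo sapiens), read by scintillation counting, tested at 10 uM; a higher number here means more inhibition at the concentration tested (going by the name of the read-out), a lower number less inhibition. In this assay compound 1 gives 1%, compound 2 gives 1% and compound 3 gives 1%. Compound 2 therefore stands level with compounds 1 and 3 at the digits shown: its nearest neighbour is compound 1 and its furthest is compound 3, and in both cases the gap lies within the usual scatter of the measurement. Among the measured compounds shown here, no pair among the measured compounds differs in a single place, so no measured step is available to gauge what a change at one position does here.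

Compound 4, `CC(C)(C)Cc1c(-c2ccco2)sc(N)c1C(=O)c1ccc(Cl)cc1`, is the next compound to be measured. It differs from compound 2 by furan-2-yl in place of 2,6-difluorophenyl on an aromatic carbon. For the measured compounds named here, with all three measured compounds sitting together at the low end of the scale and no single-place step to draw on, the step of a number 1 percentage points higher from compound 2 to compound 4 (within the scatter) is expected to be none beyond the scatter. Compound 4 is accordingly estimated to give 2%, with a range from 0% to 12%.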

Compound 4, a percentage reported as inhibition, at one concentration (the size of the read-out at that concentration, not a potency): 1%
Compound 4: the middle estimate sits 1 percentage points above what was measured, and the stated range covers the measured number.
By their numbers in this assay, from the lowest: compounds 1, 2, 3 and 4 (each within the scatter of the next).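

this assay now has its first step at a single place, with furan-2-yl in place of 2,6-difluorophenyl on the aromatic carbon next to the ring sulfur, and that step reads no change at the digits printed from compound 2 to compound 4 (within the scatter) at this position. An aromatic ring of carbon only bearing two fluorine atoms and a five-membered aromatic ring with one oxygen are therefore indistinguishable here, and with both compounds at the low end of the scale the step shows no sign of inhibition that depends on which of the two groups is present. Nothing available gives a reason for this result.

As far as these compounds go, whether an aminomethyl group, a carboxylic acid or a longer alkyl chain at this position would shift the reading remains open. Also open is whether replacing the neopentyl group or the (4-chlorophenyl)carbonyl group, for instance with a benzyl group or a pyridine-3-carbonyl group, would move the number, as the single step shown touches neither of them.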